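The source may report more compounds than this note shows. Statements on the series, on what has been measured and on what is new or still open speak of the compounds shown alone.

Measured compounds in an assay on isolated protein for inhibition of Aromatase (Homo sapiens), read by fluorescence, tested at 1 uM; on this read-out lower numbers stand for less inhibition and higher numbers for more inhibition at the one concentration tested (going by the name of the read-out):
- compound 1, `N#Cc1ccc(Oc2cccnc2)cc1NC1CCCCC1`: 33%
- compound 2, `N#Cc1ccc(Oc2cccnc2)cc1F`: 15%
- compound 3, `COc1ccc(Oc2cc(Oc3cccnc3)ccc2C#N)cc1`: 84%

Compound 3 stands highest of the three numbers; its nearest neighbour is compound 1, and compound 2 lies furthest away, both gaps beyond the scatter. Among the compounds with values here, the one step between compounds that differ in a single place is a number 18 percentage points lower from compound 1 to compound 2 (beyond the scatter), a modest fall on going from cyclohexylamino to fluoro on an aromatic carbon.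

The next compound, compound 4, `N#Cc1ccc(Oc2cccnc2)cc1Oc1cccnc1`, differs from compound 3 as follows: pyridin-3-yl in place of 4-methoxyphenyl on an oxygen on an aromatic ring. An aromatic ring with one hetero atom replaces an aromatic ring of carbon only on the oxygen on the aromatic ring. The step from compound 1 to compound 2 bears on this only indirectly: it shows that groups at this part of the shared core shift the read-out in this assay, and that the smaller group there gave the lower number. Compound 3 carries the largest group and gives the highest number. With pyridin-3-yl smaller than 4-methoxyphenyl, compound 4 is expected to sit somewhat below compound 3, the estimated step being a number 24 percentage points lower from compound 3 to compound 4 (beyond the scatter). For compound 4 the estimate in this assay is 60%, with a range from 35% to 80%.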

Compound 4, a percentage reported as inhibition, at one concentration (the size of the read-out at that concentration, not a potency): 81%
Compound 4: the middle estimate sits 21 percentage points below what was measured, outside the stated range (above it).
By their numbers in this assay, from the lowest: compound 2; then compound 1; then compounds 4 and 3 (each within the scatter of the next).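

In this assay, pyridin-3-yl in place of 4-methoxyphenyl on an oxygen on an aromatic ring gives a number 3 percentage points lower from compound 3 to compound 4 (within the scatter), so on this read-out the high number does not depend on the methoxy group or on a ring of carbon only, and the smaller ring with one hetero atom cannot be told apart from the larger one. At the aromatic carbon of the shared core, (pyridin-3-yl)oxy in place of fluoro gives a number 66 percentage points higher from compound 2 to compound 4 (beyond the scatter), and (pyridin-3-yl)oxy in place of cyclohexylamino gives a number 48 percentage points higher from compound 1 to compound 4 (beyond the scatter), which sets this group well above both earlier substituents at that place. No measurement on hand explains either the match between the two rings or the rise over fluoro and cyclohexylamino.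

From the compounds shown here alone, whether the linking oxygen itself matters remains open, and an anilino group at the same place would address that, while an unsubstituted phenyl on the oxygen would isolate the methoxy group. All the numbers come from a single concentration, so they give no potency and may not separate compound 3 and compound 4 at other concentrations.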